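A single fluoro exchange on compound 2

A few compounds are considered here, and "the series" means these few. Any claim that something is new, unique, unknown or untested is made for them only; others in the source may bear on it.

Values so far in a physicochemical assay for lipophilicity, using the shake flask method (on this read-out higher numbers stand for higher lipophilicity and lower numbers for lower lipophilicity), for the two measured compounds
- Compound 1 `C[C@H](Oc1cc2cc(C(N)=O)cc(F)c2nc1N)c1ncc(F)cc1-n1cccn1` reads 2.1
- Compound 2 `C[C@H](Oc1cc2cc(F)ccc2nc1N)c1cc(C(=O)O)ccc1-n1cccn1` reads 0.9

Compound 2 stands lowest of these two in this assay with 0.9 as its number, and compound 1 lies higher by more than the usual scatter of repeated measurements. Compound 3 `C[C@H](Oc1cc2cc(F)cc(F)c2nc1N)c1cc(C(=O)O)ccc1-n1cccn1` is compound 2 with one change (fluoro in place of hydrogen on an aromatic carbon), fluoro in place of hydrogen on an aromatic carbon. Among the compounds with values here, no pair of measured compounds shows this exchange, so the data offer no direct guide to its size. Within the data shown here, only one atom changes, so a modest rise is expected, and the expected step of a number 0.20 log units higher from compound 2 to compound 3 (within the scatter) stays within the scatter. For compound 3 the estimated value is 1.1 with an expected range (0.7 to 1.5).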

Compound 3, distribution coefficient: 1
Beside the measured number, compound 3's estimate is 0.10 log units above it; measured number inside the range.
By their numbers in this assay, from the lowest: compounds 2 and 3 (each within the scatter of the next); then compound 1.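

Putting fluoro in place of hydrogen on this aromatic carbon, ortho to a fused ring and meta to a fluoro group, gives a number 0.10 log units higher from compound 2 to compound 3 (within the scatter) in this assay. Within the data shown here, this pair is the first among the measured compounds to differ in one place, and so it gives a direct reading of this exchange: with the rest of compound 2 kept, compound 2 and compound 3 cannot be told apart on this read-out. No measurement shown offers an explanation for this outcome.

As far as these compounds go, it remains open whether a chloro or methoxy group on this same carbon would give a step beyond the scatter. Also open, from the compounds shown here alone, is whether the fluoro exchange would read the same way with a methyl ester in place of the carboxylic acid.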